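Moving the fluorine around the ring: compound 4

The source may hold more compounds than are shown below. What is called first, only, known or untested is meant among the compounds shown, and "the series" means these compounds.

Compound 1 `O=C(Nc1ccc2cccnc2c1)c1ccc(-c2ccccc2F)nc1` is measured in an in vitro functional assay on 1321-N1 cells for antagonist activity at transient receptor potential cation channel subfamily V member 1 (Homo sapiens), read by FLIPR and calcium flux (on this read-out lower numbers stand for lower potency and higher numbers for higher potency (the scale is a negative logarithm)), where compound 1 gives 8.7, the highest of the three numbers seen. Compound 3 `O=C(Nc1ccc2cccnc2c1)c1ccc(-c2ccc(F)cc2)nc1` gives 8.2 in this assay, and compound 2 `Cc1nc(-c2ccc(F)cc2)ccc1C(=O)Nc1ccc2c(C)n[nH]c2c1`, which differs in several places, gives 6.9.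

Compound 4 `O=C(Nc1ccc2cccnc2c1)c1ccc(-c2cccc(F)c2)nc1` has the same atoms as compound 1 joined differently: 3-fluorophenyl in place of 2-fluorophenyl on an aromatic carbon.

Going by the values given here, the only step that bears on this is the one from compound 1 to compound 3, a number 0.50 log units lower from compound 1 to compound 3 (beyond the scatter), which also moves the fluorine on the same ring. A smaller shift of the fluorine is therefore expected to cost somewhat less, and the step of a number 0.30 log units lower from compound 1 to compound 4 (within the scatter) is estimated as a modest loss. Compound 4 is expected to give 8.4, somewhere between 7.9 and 8.9.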

Compound 4, negative logarithm of the antagonist equilibrium constant: 8.6
Compound 4: the middle estimate sits 0.20 log units below what was measured; low and high end bracket the measured number.
By their numbers in this assay, from the lowest: compound 2; then compound 3; then compounds 4 and 1 (each within the scatter of the next).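

Moving the fluorine around this ring does not give a steady slide in potency. The 3-fluorophenyl and 2-fluorophenyl compounds cannot be told apart, with a number 0.10 log units lower from compound 1 to compound 4 (within the scatter), whereas a number 0.40 log units higher from compound 3 to compound 4 (beyond the scatter), so among these three placements only 4-fluorophenyl stands lower. Nothing available explains why the placement matters in this way. Still open, from the compounds shown here alone, is whether a group other than fluorine, such as chlorine, methoxy or an amine, would fare as well on this ring. Also open, going by these compounds, is how a phenyl ring carrying two fluorines would compare.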